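Cinnamamide series: removing one chloro from compound 3

The source may hold more compounds than are shown below. What is called first, only, known or untested is meant among the compounds shown, and "the series" means these compounds.

Compound 3 `O=C(/C=C/c1ccccc1)NCc1ccc(Cl)cc1Cl` gives 43% in a functional assay on the whole organism for inhibition, with Brassica rapa subsp. chinensis as the target, with a stated time of 3 days, tested at 100 ppm (on this read-out higher numbers stand for more inhibition of growth at the one concentration tested and lower numbers for less inhibition of growth), second highest of the three numbers: compound 1 `O=C(/C=C/c1ccccc1)NCc1ccccc1Cl` gives 88% and compound 2 `CCc1ccccc1NC(=O)/C=C/c1ccccc1` gives 21%. Compound 4 `O=C(/C=C/c1ccccc1)NCc1ccc(Cl)cc1` differs from compound 3 by hydrogen in place of chloro on an aromatic carbon, on an aromatic carbon of a six-membered aromatic ring of carbon only, ortho to a large group and meta to a chloro group. Going by the values given here, the only measured step touching a chloro on this ring is a number 45 percentage points lower from compound 1 to compound 3 (beyond the scatter), which concerns a different position and so bears on the present change only loosely; the chloro that remains in compound 4 is the one whose arrival lowered the number. Compound 4 is therefore expected to show a step of a number 1 percentage points lower from compound 3 to compound 4 (within the scatter), with no clear direction beyond the scatter. The estimate for compound 4 is 42%, within 15% to 75%.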

Compound 4, percent growth inhibition at one concentration: 44%
Compound 4: the middle estimate sits 2 percentage points below what was measured; low and high end bracket the measured number.
By their numbers in this assay, from the lowest: compound 2; then compounds 3 and 4 (each within the scatter of the next); then compound 1.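

In this assay the change reads as a number 1 percentage points higher from compound 3 to compound 4 (within the scatter) and so, with the other chloro present, hydrogen and chloro at this position ortho to a large group cannot be told apart. This differs in size from a number 45 percentage points lower from compound 1 to compound 3 (beyond the scatter) at the other ring position, so the two chloro positions do not count alike in this pair of steps. Nothing available explains this difference.

On these data alone, whether this position stays as undemanding with methoxy or fluoro in place of chloro remains open. So does the result for a benzyl group carrying no chloro at all.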